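This account rests on a few compounds, and the source may have more. Where it says the series, first, only, none or still open, it means among the compounds named here.

Measured so far in a functional assay on L1210 cells (Mus musculus) for cytotoxicity, with a stated time of 48 h; on this read-out higher numbers stand for weaker inhibition and lower numbers for stronger inhibition:

compound 1 (`COc1cc2c(c(O)c1C)C(=O)CCC2O`) gives 25 ug/mL
compound 2 (`COc1c(C)c(OCC=C(C)C)c2c(c1C(=O)O)C(=O)OC2`) gives 50 ug/mL

Among the measured compounds shown here, only two values are available, and they lie within the usual scatter of each other, so compound 2 cannot be separated from compound 1 on these numbers. Compound 3 (`COC(=O)c1c(OC)c(C)c(OCC=C(C)C)c2c1C(=O)OC2`) is compound 2 with one structural change, methyl in place of hydrogen on an oxygen next to a carbonyl group, which turns carboxy into methoxycarbonyl. For the measured compounds named here, no measured pair shows this change, so the expectation is cautious. In this assay only a small move towards a lower number is expected, not one beyond the scatter, and the estimated step of a 1.7-fold lower number from compound 2 to compound 3 (0.22 log units; within the scatter) reflects that. For compound 3 the expected value is 30 ug/mL with an estimated range from 10 ug/mL to 80 ug/mL in this assay.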

Compound 3, half-maximal inhibitory concentration: 25 ug/mL
Compound 3: middle estimate off by 1.2-fold (0.08 log units), on the high side; the range from low to high includes it.
By their numbers in this assay, from the lowest: compounds 1, 3 and 2 (each within the scatter of the next).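

In this assay, among the compounds shown here, the methyl in place of hydrogen on an oxygen next to a carbonyl group, which turns carboxy into methoxycarbonyl, gives a 2.0-fold lower number from compound 2 to compound 3 (0.30 log units; within the scatter) and so provides the first comparison of two compounds that differ in one place. For the compounds shown here, at this position, the change from carboxy to methoxycarbonyl produces no step that can be told apart from repeat measurements, so these values do not show that the hydrogen on this oxygen is needed for activity. No measurement available here offers an explanation for this result.

On these data alone, it remains open whether a longer chain on this oxygen, or an amide in place of the methoxycarbonyl group, would give a step beyond the scatter. As far as these compounds go, the effect of replacing the other groups on the shared core also remains open.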